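Replacing benzyl with (4-cyanophenyl)carbonyl on the shared core

The compounds below may be only part of what the source reports. "The series", "measured", "known", "first", "only" and "open" are said of these compounds alone.

Among the measured compounds shown here, two measured compounds frame this series so far. In a functional assay on MKN-45 cells (Homo sapiens) for cytotoxicity (a higher number here means a weaker inhibitor, a lower number a stronger inhibitor), compound 1 `COc1ccc(S(=O)(=O)N2CCc3cccc(NC(=O)c4ccc([N+](=O)[O-])cc4)c32)cc1` gives 95 nM. Compound 2 `COc1ccc(S(=O)(=O)N2CCc3cccc(NCc4ccccc4)c32)cc1` reaches only a limit of the assay, > 10000 nM, so it has no numerical value and stands at the weak end of the two results.

Compound 3 `COc1ccc(S(=O)(=O)N2CCc3cccc(NC(=O)c4ccc(C#N)cc4)c32)cc1` differs from compound 2 in one place, on a nitrogen on an aromatic ring: (4-cyanophenyl)carbonyl in place of benzyl ((4-cyanophenyl)carbonyl in place of benzyl on a nitrogen on an aromatic ring).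

For the measured compounds named here, no measured step isolates a single change in this assay, so the expectation is indirect. The nearest numerical reference for compound 3 is compound 1 at 95 nM, and the carbonyl that enters is what moves the structure away from compound 2. A large move towards stronger inhibition is therefore expected, well beyond the scatter. The estimated size of that move is an at least 66-fold lower number from compound 2 to compound 3 (1.82 log units; beyond the scatter). For compound 3 the expected value is 150 nM, with an estimated range of 40 nM to 600 nM.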

Compound 3, half-maximal inhibitory concentration: 89 nM
Compound 3: the middle estimate sits 1.7-fold (0.23 log units) above what was measured, and the stated range covers the measured number.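

In this assay, (4-cyanophenyl)carbonyl in place of benzyl on a nitrogen on an aromatic ring gives an at least 110-fold lower number from compound 2 to compound 3 (2.05 log units; beyond the scatter), so the change at this position now has a measured lower bound on its size, one that lies beyond the scatter. The figure for compound 2 is a limit of the assay and not a number, so the true size of the step stays unknown: the limit of > 10000 nM in this assay, at which 1 of the 3 values shown sits.

Cyano in place of nitro on an aromatic carbon gives a 1.1-fold lower number from compound 1 to compound 3 (0.03 log units; within the scatter), which lies within the scatter, so the nitro group of compound 1 is not needed for a value of this order, as compound 3 carries a cyano group instead and reads alike.

The step from benzyl brings in the carbonyl and the cyano group together, so the compounds shown leave open which of the two carries the gain; a plain benzoyl group and a 4-cyanobenzyl group would separate them. Also open, from the compounds shown here alone, is whether the same holds for a carboxylic acid or an amine in place of the cyano group.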